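Allyloxymethyl in place of carbamoyl: cytotoxicity notes

A few compounds are considered here, and "the series" means these few. Any claim that something is new, unique, unknown or untested is made for them only; others in the source may bear on it.

Measured in an ADME assay on Huh-5-2 cells (Homo sapiens) for cytotoxicity, with a stated time of 3 days; a higher number here means that more compound is tolerated, a lower number that less compound is tolerated:
- compound 1 `CCOC(=O)c1csc([C@H]2[C@@H](COC)C[C@@](CC(C)C)(C(=O)O)N2C(=O)c2ccc(C(C)(C)C)c(OC)c2)n1`: 200000 nM
- compound 2 `COC[C@H]1C[C@@](CC(C)C)(C(=O)O)N(C(=O)c2ccc(C(C)(C)C)c(OC)c2)[C@H]1C(N)=O`: > 120000 nM (a limit)

In this assay compound 2 stands only at a limit, > 120000 nM. Compound 3 `C=CCOC[C@H]1[C@@H](COC)C[C@@](CC(C)C)(C(=O)O)N1C(=O)c1ccc(C(C)(C)C)c(OC)c1` carries (allyloxy)methyl in place of carbamoyl on a saturated ring carbon. For the measured compounds named here, the one measured step at this carbon, a step that the limit leaves unreadable from compound 1 to compound 2, gives no size to carry over, as the limit of > 120000 nM in this assay, at which 1 of the 2 values shown sits, shows. The expectation therefore rests on compound 1 at 200000 nM, and no step beyond the scatter is expected. The expected step is a step that the limit leaves unreadable from compound 2 to compound 3. For compound 3 the estimated value is 150000 nM, with an expected range of 60000 nM to 300000 nM.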

Compound 3, half-maximal cytotoxic concentration: > 120000 nM
Compound 3: a limit, no number; the forecaster's own chance of this, stated with the estimate: 40%; the middle value lies beyond the limit too.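

No step can be read among compound 1, compound 2 and compound 3 in this assay, and the reason is this: the limit of > 120000 nM in this assay, at which 2 of the 3 values shown sit.

The compounds shown leave open how far compound 2 and compound 3 differ from each other or from compound 1 in tolerated concentration.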